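From compound 1 to compound 3: sulfur for selenium

The source may hold more compounds than are shown below. What is called first, only, known or untested is meant among the compounds shown, and "the series" means these compounds.

Compound 1 `CC(=O)Oc1ccccc1C(=O)OCC[Se]C#N` gives 36100 nM in a functional assay on PANC-1 cells (Homo sapiens) for antiproliferative activity, read by MTT assay, with a stated time of 48 h (a lower number here means a stronger inhibitor, a higher number a weaker inhibitor), the highest of the two numbers in hand; compound 2 `CC(=O)Oc1ccccc1C(=O)[Se]CC[Se]C(=O)c1ccccc1OC(C)=O` gives 13500 nM, and the gap between the two lies beyond the usual scatter. Compound 3 `CC(=O)Oc1ccccc1C(=O)NCCSC#N` differs from compound 1 in one place: a group of 6 heavy atoms (3 carbon, 2 nitrogen, 1 sulfur; no ring) in place of a group of 6 heavy atoms (3 carbon, 1 nitrogen, 1 oxygen, 1 selenium; no ring), on a carbonyl carbon. Going by the values given here, no measured pair carries this same change, so the size of the step rests on expectation alone: the expected step is a 1.4-fold higher number from compound 1 to compound 3 (0.14 log units; within the scatter), a modest shift toward a higher number in this assay that may still fall within the scatter. Compound 3 is accordingly estimated at 50000 nM, with a range of 20000 nM to 130000 nM.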

Compound 3, half-maximal inhibitory concentration: 17700 nM
Estimate against measurement, compound 3: 2.8-fold (0.45 log units) above; the measured number lies below the stated range.
By their numbers in this assay, from the lowest: compounds 2 and 3 (each within the scatter of the next); then compound 1.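

On the carbonyl carbon, (2-(cyanosulfanyl)ethyl)amino in place of the group bearing oxygen and selenium gives a 2.0-fold lower number from compound 1 to compound 3 (0.31 log units; beyond the scatter) in this assay and is a modest step. Selenium is therefore not required at this position for activity on this scale, and the position accepts a change of both the linking atom and the chalcogen. No measurement available here bears on the cause of this step.

Going by these compounds alone, the single step leaves the nitrogen-for-oxygen and sulfur-for-selenium exchanges unseparated. Also open, on these data alone, is the effect of a longer chain here, such as (3-(cyanosulfanyl)propyl)amino.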